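This account rests on a few compounds, and the source may have more. Where it says the series, first, only, none or still open, it means among the compounds named here.

Measured so far:
Compound 1 `C/C(=C\CCc1ccoc1)C[C@@H]1C=C(C/C=C/c2ccoc2)C(=O)O1`: 32.3 ug/mL
Compound 2 `COC1C=C(CCC/C(C)=C/C=C/[C@@H](C)CC/C=C(/C)C[C@H]2OC(=O)C(C)=C2O)C(=O)O1`: > 30 ug/mL, a limit
Compound 3 `CC1=C(O)[C@@H](C/C(C)=C\CC[C@H](C)/C=C/C=C(\C)CCCC2=CCN(CC(=O)O)C2=O)OC1=O`: > 30 ug/mL, a limit

In a functional assay on SK-OV-3 cells (Homo sapiens) for cytotoxicity (on this read-out higher numbers stand for an effect only at larger amounts of compound and lower numbers for an effect already at smaller amounts), compound 3 stands at the limit of > 30 ug/mL in this assay, at which 2 of the 3 values shown sit. It therefore has no exact number, and only compound 1 has one.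

Compound 4 `CC1=C(O)[C@@H](C/C(C)=C\CC[C@H](C)/C=C/C=C(\C)CCCC2=CC(=O)N(CC(=O)O)C2)OC1=O` keeps the atoms of compound 3 but joins them differently: a group of 10 heavy atoms (6 carbon, 1 nitrogen, 3 oxygen; one five-membered non-aromatic ring with 1 hetero atom) in place of a group of 10 heavy atoms (6 carbon, 1 nitrogen, 3 oxygen; one five-membered non-aromatic ring with 1 hetero atom), on a saturated chain carbon, three bonds along the chain from a double-bonded chain carbon. The change stays on a saturated chain carbon, three bonds along the chain from a double-bonded chain carbon.

Within the data shown here, one measured step touches this place, a step that the two limits leave unreadable from compound 2 to compound 3. Its two ends are both limits, so it gives no size to carry over. With no readable step to suggest a direction, no shift beyond the usual scatter is expected in this assay. The estimated step is a step that the limit leaves unreadable from compound 3 to compound 4. For compound 4 the expected value is 35 ug/mL, with an estimated range from 20 ug/mL to 60 ug/mL. The assay may well report only a limit again.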

Compound 4, concentration for half-maximal effect: > 30 ug/mL
Compound 4: only a limit was reported; the forecaster's own chance of this, stated with the estimate: 70%; the middle value does not contradict the limit.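

Compound 2, compound 3 and compound 4 all end at a limit rather than a number, so no step among them can be read: the limit of > 30 ug/mL in this assay, at which 3 of the 4 values shown sit.

As far as these compounds go, what stays open is whether joining the same atoms differently, as in compound 3 and compound 4, changes the effect in this assay at all.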